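The source may hold more compounds than are shown below. What is called first, only, known or untested is meant among the compounds shown, and "the series" means these compounds.

Two compounds share one core, differing only in the group on the benzamide ring. Compound 1 `CN(C)c1ccc(C(=O)N2CCC(n3cncc3-c3ccc(OS(=O)(=O)c4cccc5cnccc45)cc3)CC2)cc1` carries a dimethylamino group there, and in an assay on THP-1 cells for antagonist activity at P2X purinoceptor 7 (Homo sapiens), read by ELISA, with a stated time of 30 min (a higher number here means a weaker inhibitor, a lower number a stronger inhibitor), compound 1 gives 2.19 nM. Compound 2 `CC(C)c1ccc(C(=O)N2CCC(n3cncc3-c3ccc(OS(=O)(=O)c4cccc5cnccc45)cc3)CC2)cc1` carries an isopropyl group instead; in this assay compound 2 gives 37 nM, the higher of the two numbers measured, and the step of a 17-fold higher number from compound 1 to compound 2 (1.23 log units; beyond the scatter) is beyond the usual scatter.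

Compound 3 `CC(C)(O)c1ccc(C(=O)N2CCC(n3cncc3-c3ccc(OS(=O)(=O)c4cccc5cnccc45)cc3)CC2)cc1` differs from compound 2 by a hydroxy in place of hydrogen on a saturated chain carbon bound to an aromatic carbon and two saturated chain carbons. For the measured compounds named here, the only measured step, from dimethylamino to isopropyl, does not test a hydroxy at this position, so it gives no clear direction. For compound 3 in this assay the expected step of a 1.2-fold lower number from compound 2 to compound 3 (0.09 log units; within the scatter) is therefore small, not beyond the scatter, with the estimate 30 nM and a range from 8 nM to 120 nM.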

Compound 3, half-maximal inhibitory concentration: 4.7 nM
For compound 3 the middle estimate is 6.4-fold (0.81 log units) above the measured one; measured number outside the range, below it.
By their numbers in this assay, from the lowest: compound 1; then compound 3; then compound 2.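

Adding one hydroxy to the isopropyl group matters at this position: in this assay it gives a 7.9-fold lower number from compound 2 to compound 3 (0.90 log units; beyond the scatter) and so wins back much of the ground lost when dimethylamino gave way to isopropyl. The 1-hydroxy-1-methylethyl group also comes close to dimethylamino, although compound 1 keeps a modest lead, with a 2.1-fold higher number from compound 1 to compound 3 (0.33 log units; beyond the scatter) remaining in this comparison, so a nitrogen in this group is not needed for a low number among the compounds shown. Nothing available here explains why the hydroxy has this effect.

The compounds shown leave open how a methoxy group, which replaces the hydroxy hydrogen with a methyl, or a longer chain carrying the hydroxy would compare. They also leave open how a carboxylic acid or a primary amine would fare at this position.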